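A Second Methoxy Group Added to Two Related Compounds

A few compounds are considered here, and "the series" means these few. Any claim that something is new, unique, unknown or untested is made for them only; others in the source may bear on it.

Compound 1 `COc1ccc(NC(=O)CCc2cccc3c2B(O)OC3)cc1` is tested in a functional assay on SK-OV-3 cells (Homo sapiens) for antiproliferative activity, read by MTT assay, with a stated time of 72 h (on this read-out lower numbers stand for stronger inhibition and higher numbers for weaker inhibition), where compound 1 gives 900 nM. Compound 2 `COc1ccc(NC(=O)CCc2cccc3c2B(O)OC3)cc1OC` differs from it by methoxy in place of hydrogen on an aromatic carbon. In this assay compound 2 is reported only as a limit, > 100000 nM. The step is an at least 110-fold higher number from compound 1 to compound 2 (2.04 log units; beyond the scatter); that its size is known only as a lower bound follows from the limit of > 100000 nM in this assay, at which 2 of the 3 values shown sit.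

Compound 3 `COc1cccc(-c2cccc(NC(=O)CCc3ccc4c(c3)COB4O)c2)c1` is built on another core; the difference between the two cores is not broken down here. In this assay compound 3 is likewise reported only as a limit, > 100000 nM.

Compound 4 `COc1cc(OC)cc(-c2cccc(NC(=O)CCc3ccc4c(c3)COB4O)c2)c1` differs from compound 3 by methoxy in place of hydrogen on an aromatic carbon. Within the data shown here, this is the same kind of change as the one from compound 1 to compound 2, but not the same: in compound 2 the entering methoxy sits ortho to a methoxy group, while in compound 4 it sits meta to a methoxy group.

Since compound 3 already sits at the limit of this assay, no further worsening can be read there. The step from compound 3 to compound 4 is expected to be a step that the limit leaves unreadable from compound 3 to compound 4, resting on the limit reported for compound 3 and on the direction of an at least 110-fold higher number from compound 1 to compound 2 (2.04 log units; beyond the scatter). Compound 4 is therefore expected to give 150000 nM in this assay, most likely again as a limit, within an estimated range from 40000 nM to 600000 nM.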

Compound 4, half-maximal inhibitory concentration: 93000 nM
The estimate for compound 4 lay 1.6-fold (0.21 log units) above the measured number; the range from low to high includes it.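

In this assay, adding a methoxy group in place of a hydrogen on an aromatic carbon does not give the same outcome on the two cores: it produces an at least 110-fold higher number from compound 1 to compound 2 (2.04 log units; beyond the scatter), whereas the other pair shows an at least 1.0-fold lower number from compound 3 to compound 4 (0.03 log units; that floor lies within the scatter). Set side by side, the two steps are clearly apart, so the large loss seen on the core of compound 1 cannot be assumed to carry over to the core of compound 3: the same change on two cores in this assay, an at least 110-fold higher number (2.04 log units; beyond the scatter) from compound 1 to compound 2 and an at least 1.0-fold lower number (0.03 log units; that floor lies within the scatter) from compound 3 to compound 4, at least 110-fold (2.07 log units) apart, beyond the scatter of two such steps This does not show that the change is harmless or neutral on the core of compound 3, and it gives the exact size of neither step, as each one rests on a limit: the limit of > 100000 nM in this assay, at which 2 of the 4 values shown sit.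

The compounds shown leave open how either core would respond to a different group in place of the added methoxy, such as a hydroxyl group, an amine or a carboxylic acid. They also leave open whether the gap between the two steps belongs to the cores themselves or to the other structural differences between the two pairs, including where the added methoxy sits.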